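Swapping dimethylamino for carbamoyl on a weak core

A few compounds are considered here, and "the series" means these few. Any claim that something is new, unique, unknown or untested is made for them only; others in the source may bear on it.

Compound 1 `O=C(O)c1cnc2cc(OCc3c(Cl)c(Cl)c(Cl)c(Cl)c3Cl)ccc2c1O` gives 4790 nM in an assay on isolated protein with malate dehydrogenase, mitochondrial (Sus scrofa) as the target; a higher number here means a weaker inhibitor, a lower number a stronger inhibitor.
Compound 2 `CN(C)c1ccc2c(O)c(C(=O)O)cnc2c1` gives 479000 nM in this assay.
Compound 3 `O=C(O)c1cnc2cc(OCCOc3ccc(Br)cc3)ccc2c1O` gives 5130 nM in this assay.

Among these three, compound 2 stands at the highest number, which means it is the weakest inhibitor of the set. Compound 1 and compound 3 both carry a large ether-linked aromatic group on the shared core and land at much lower numbers, and both of those gaps lie well beyond the usual scatter. Compound 2 carries only a small dimethylamino group there.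

Compound 4 `NC(=O)c1ccc2c(O)c(C(=O)O)cnc2c1` keeps the same core and differs from compound 2 in one place: carbamoyl in place of dimethylamino on an aromatic carbon. For the measured compounds named here, no measured pair shows this particular swap, so nothing here tells how it will play out. The small group stays small, unlike the large groups of compound 1 and compound 3, so the step from compound 2 to compound 4 is expected to be modest, most likely not beyond the scatter, and its direction is open. The expected step is a 1.2-fold lower number from compound 2 to compound 4 (0.08 log units; within the scatter). Compound 4 is therefore estimated to give about 400000 nM, with a plausible span from 100000 nM to 1500000 nM.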

Compound 4, half-maximal inhibitory concentration: 741000 nM
For compound 4 the middle estimate is 1.9-fold (0.27 log units) below the measured one; the measured number falls inside the stated range.
By their numbers in this assay, from the lowest: compounds 1 and 3 (each within the scatter of the next); then compounds 2 and 4 (each within the scatter of the next).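

Putting carbamoyl in place of dimethylamino on this aromatic carbon gives a 1.5-fold higher number from compound 2 to compound 4 (0.19 log units; within the scatter) in this assay, so the two compounds cannot be told apart in this measurement. The swap keeps the count at 3 heavy atoms but replaces carbon with oxygen and adds 1 hydrogen-bond donor, and neither difference produces a change beyond the scatter. This pair therefore gives the first direct reading at this position, and both compounds remain at the high end of the numbers shown. No accompanying measurement explains why this swap leaves the reading within the scatter.

On these data alone, it remains open whether a primary amine, a methyl ester or a longer alkyl chain on this carbon would give a step beyond the scatter. A single pair also cannot show whether carbamoyl and dimethylamino would read alike on a core that differs elsewhere.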